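From hydroxy to amino on a shared core

The source may report more compounds than this note shows. Statements on the series, on what has been measured and on what is new or still open speak of the compounds shown alone.

compound 1 `Nc1cccc(/C=C/c2ccccc2)c1`: 14 ug/mL
compound 2 `Nc1cccc(/C=C/c2ccc(O)cc2)c1`: 6 ug/mL
compound 3 `COc1ccc(/C=C/c2cccc(O)c2)cc1`: 21 ug/mL

These three values come from a functional assay on MCF7 cells (Homo sapiens) for inhibition, read by MTT assay, with a stated time of 2 days (on this read-out higher numbers stand for weaker inhibition and lower numbers for stronger inhibition), and show how much of each compound is needed for a half-maximal effect. Compound 3 (at 21 ug/mL) lies within the usual scatter of compound 1 (at 14 ug/mL). Compound 2 (at 6 ug/mL) gives a lower number than compound 3, and that gap is beyond the scatter.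

Compound 4 `COc1ccc(/C=C/c2cccc(N)c2)cc1` differs from compound 3 in one place: amino in place of hydroxy on an aromatic carbon is the change, amino in place of hydroxy on an aromatic carbon. Among the compounds with values here, no measured step makes this swap. Within the data shown here, the only measured step is a 2.3-fold lower number from compound 1 to compound 2 (0.37 log units; beyond the scatter) and its change is hydroxy in place of hydrogen on an aromatic carbon. That modest step is a different change, so it bears on this one only indirectly.

Amino is also present in compound 2 (at 6 ug/mL) and in compound 1 (at 14 ug/mL). This points to a somewhat lower number in this assay for compound 4, though the evidence is thin. The expected step is a 1.8-fold lower number from compound 3 to compound 4 (0.24 log units; within the scatter) and it may well stay within the scatter. Compound 4 is estimated at 12 ug/mL (expected range 5 ug/mL to 28 ug/mL).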

Compound 4, half-maximal inhibitory concentration: 23 ug/mL
Estimate against measurement, compound 4: 1.9-fold (0.28 log units) below, within the range that was stated.
By their numbers in this assay, from the lowest: compound 2; then compounds 1, 3 and 4 (each within the scatter of the next).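

In this assay the swap of hydroxy for amino on an aromatic carbon, meta to a large group, gives a 1.1-fold higher number from compound 3 to compound 4 (0.04 log units; within the scatter) and so, with a methoxy group present on the shared core, this read-out does not tell the two groups apart. Compound 4 also shows how the methoxy group itself reads: methyl in place of hydrogen on the oxygen gives a 3.8-fold higher number from compound 2 to compound 4 (0.58 log units; beyond the scatter) and this is a clear move toward weaker inhibition, whereas adding the methoxy group to a core that lacks it gives a 1.6-fold higher number from compound 1 to compound 4 (0.22 log units; within the scatter) and this cannot be told from no change. Nothing measured on these compounds offers a reason for either result.

Still open, as far as these compounds go, is whether hydroxy and amino would also match on the core of compound 1, which carries no methoxy group, and whether a carboxylic acid or a methylamino group in the same place would read any differently. From the compounds shown here alone, it is also open whether a longer chain than methyl on that oxygen, such as ethyl, would read like the methoxy group of compound 4 or would move the number further.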